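Spiro-oxindole series: aryl variation on the triazole nitrogen

The compounds below may be only part of what the source reports. "The series", "measured", "known", "first", "only" and "open" are said of these compounds alone.

Measured compounds:
compound 1 `N#CC1=C(N)Oc2c(N)cc3nc4ccccc4nc3c2C12C(=O)N(Cc1cnnn1-c1ccc(F)cc1)c1ccccc12` — > 50000 nM
compound 2 `COc1ccc(-n2nncc2CN2C(=O)C3(C(C#N)=C(N)Oc4c(N)cc5nc6ccccc6nc5c43)c3ccccc32)cc1` — > 50000 nM
compound 3 `CCOc1ccccc1-n1nncc1CN1C(=O)C2(C(C#N)=C(N)Oc3c(N)cc4nc5ccccc5nc4c32)c2ccccc21` — > 50000 nM

The three measured compounds share one core and differ only in the aryl group on the triazole nitrogen. In a functional assay on MCF7 cells (Homo sapiens) for antiproliferative activity, read by MTT assay, with a stated time of 48 h (on this read-out higher numbers stand for weaker inhibition and lower numbers for stronger inhibition), compound 1 gives only a limit, > 50000 nM. In this assay compound 2 likewise gives only a limit, > 50000 nM. In this assay compound 3 also gives only a limit, > 50000 nM. Compound 3 therefore stands at the limit of > 50000 nM in this assay, at which 3 of the 3 values shown sit, together with every other value shown; no number places it above or below its neighbours.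

The unmeasured compound 4 `Cc1ccc(Cl)cc1-n1nncc1CN1C(=O)C2(C(C#N)=C(N)Oc3c(N)cc4nc5ccccc5nc4c32)c2ccccc21` is reached from compound 3 by 5-chloro-2-methylphenyl in place of 2-ethoxyphenyl on an aromatic nitrogen. Among the compounds with values here, the steps that bear on this change are a step that the two limits leave unreadable from compound 1 to compound 2, a step that the two limits leave unreadable from compound 1 to compound 3 and a step that the two limits leave unreadable from compound 2 to compound 3; none of them has a readable size, since both ends sit at the limit. Nothing among the shown values indicates that an aryl change on this nitrogen moves this assay out of the limit region, and no direction can be read.

Compound 4 is therefore expected to remain at or near the limit, with an estimated step that the limit leaves unreadable from compound 3 to compound 4 from compound 3. The estimate for compound 4 in this assay is 80000 nM, within 30000 nM to 300000 nM.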

Compound 4, half-maximal inhibitory concentration: 43500 nM
Compound 4: the middle estimate sits 1.8-fold (0.26 log units) above what was measured, within the range that was stated.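

In this assay, within the data shown here, the 5-chloro-2-methylphenyl group on the aromatic nitrogen gives the only reading that is a number and not a limit, with compound 4 at 43500 nM. Against the three earlier compounds the change reads as an at least 1.1-fold lower number from compound 3 to compound 4 (0.06 log units; that floor lies within the scatter), an at least 1.1-fold lower number from compound 2 to compound 4 (0.06 log units; that floor lies within the scatter) and an at least 1.1-fold lower number from compound 1 to compound 4 (0.06 log units; that floor lies within the scatter); each of these is only a floor, so the true size of the step stays unknown, and the floor alone does not clear the scatter. Compound 1, compound 2 and compound 3 remain limits and share one position: the limit of > 50000 nM in this assay, at which 3 of the 4 values shown sit.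

The compounds shown do not separate the chloro group from the methyl group on the aryl ring of compound 4, as no compound here carries one without the other. Also open, on these data alone, is what a phenyl ring bearing an amine or a carboxylic acid would give on this nitrogen, and whether any aryl group at this position can bring the number far from that of compound 4 in this assay.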